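The source may report more compounds than this note shows. Statements on the series, on what has been measured and on what is new or still open speak of the compounds shown alone.

Working notes on the series, all on the shared core and differing at one aromatic carbon. In a functional assay (muscle tissue) with Cavia porcellus as the target (on this read-out higher numbers stand for an effect only at larger amounts of compound and lower numbers for an effect already at smaller amounts), compound 1 `COC(=O)C1=C(C)N=C(C)/C(=C(\O)OC)C1c1cccc(N(C)C)c1` gives 891 nM, compound 2 `COC(=O)C1=C(C)N=C(C)/C(=C(\O)OC)C1c1cccc(C(F)(F)F)c1` gives 74.1 nM and compound 3 `COC(=O)C1=C(C)N=C(C)/C(=C(\O)OC)C1c1cccc(C#N)c1` gives 34.7 nM, the lowest of the three numbers. Next comes compound 4 `COC(=O)C1=C(C)N=C(C)/C(=C(\O)OC)C1c1cccc([N+](=O)[O-])c1`, with nitro in place of cyano on an aromatic carbon. Going by the values given here, no measured step has nitro entering or cyano leaving, so the guidance is indirect. The two large steps, a 12-fold lower number from compound 1 to compound 2 (1.08 log units; beyond the scatter) and a 26-fold lower number from compound 1 to compound 3 (1.41 log units; beyond the scatter), both have dimethylamino leaving and say little about this swap. The closer guide is the modest step of a 2.1-fold lower number from compound 2 to compound 3 (0.33 log units; beyond the scatter), an exchange that involves neither dimethylamino nor nitro. A modest step in this assay is therefore expected, tentatively toward a lower number, and a result within the scatter of compound 3 would not surprise. The expected change is a 2.3-fold lower number from compound 3 to compound 4 (0.36 log units; beyond the scatter). For compound 4 the estimated value is 15 nM, with an expected range of 4 nM to 45 nM.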

Compound 4, half-maximal effective concentration: 3.98 nM
Estimate against measurement, compound 4: 3.8-fold (0.58 log units) above; the measured number lies below the stated range.
By their numbers in this assay, from the lowest: compound 4; then compound 3; then compound 2; then compound 1.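

In this assay, going by these compounds alone, the position proves more sensitive to the choice of group than the modest 2.1-fold lower number from compound 2 to compound 3 (0.33 log units; beyond the scatter) suggested, since the single exchange of nitro for cyano gives an 8.7-fold lower number from compound 3 to compound 4 (0.94 log units; beyond the scatter) and so a much larger change among two groups that already gave low numbers. The wider comparisons, a 19-fold lower number from compound 2 to compound 4 (1.27 log units; beyond the scatter) and a 220-fold lower number from compound 1 to compound 4 (2.35 log units; beyond the scatter), put nitro at the low end of the four groups on this aromatic carbon, with every step beyond the scatter. Nothing at hand accounts for the size of this change.

As far as these compounds go, whether the low number belongs to nitro alone or is shared by a carboxylic acid, a methyl ester or a chlorine on the same carbon stays open. From the compounds shown here alone, whether the order of these four groups holds on the other aromatic carbons of the ring is also open.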